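This account rests on a few compounds, and the source may have more. Where it says the series, first, only, none or still open, it means among the compounds named here.

Measured so far:
- Compound 1, `CC(Oc1ccc(Cl)cc1Cl)C(=O)NCc1ccccc1`: 95000 nM
- Compound 2, `Cc1ccc(CNC(=O)C(C)Oc2ccc(Cl)cc2Cl)cc1`: 25000 nM

Compound 1 holds the highest of the two numbers measured in an ADME assay on CHO cells (Cricetulus griseus) for cytotoxicity, read by LDH release; on this read-out lower numbers stand for stronger inhibition and higher numbers for weaker inhibition; its nearest neighbour is compound 2, which lies a 3.8-fold lower number from compound 1 to compound 2 (0.58 log units; beyond the scatter).

Compound 3, `COc1cccc(CNC(=O)C(C)Oc2ccc(Cl)cc2Cl)c1`, has not yet been measured. Against compound 1 the change is methoxy in place of hydrogen on an aromatic carbon, and the methoxy sits meta to a large group on the six-membered aromatic ring of carbon only.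

For the measured compounds named here, the one step that bears on this is the one from compound 1 to compound 2, a modest step and beyond the scatter, where a different group enters on the same ring. Going by the values given here, it is the only guide; no methoxy has been tried. A change in the same direction is expected for compound 3 in this assay, but smaller and less certain, since the group and its place differ from compound 2.

Compound 3 is therefore expected to give 50000 nM, within 20000 nM to 150000 nM, a step of a 1.9-fold lower number from compound 1 to compound 3 (0.28 log units; within the scatter) relative to compound 1.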

Compound 3, half-maximal inhibitory concentration: > 100000 nM
Compound 3 ended at the assay's limit; the forecaster's own chance of this, stated with the estimate: 20%; middle value at least 2.0-fold (0.30 log units) from the limit.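

In this assay compound 3 gives > 100000 nM, which is a limit of the assay and not a number. The step reads an at least 1.0-fold higher number from compound 1 to compound 3 (0.02 log units; that floor lies within the scatter), so only a floor is known, and methoxy in place of hydrogen on an aromatic carbon, meta to a large group, shows no lowering of the number. Substitution on this ring therefore does not lower the number as a rule: the methyl change gave a 3.8-fold lower number from compound 1 to compound 2 (0.58 log units; beyond the scatter), and the methoxy change does not repeat it.

The compounds shown do not separate the effect of the group from that of its place: compound 2 and compound 3 differ in both. Going by these compounds, how a fluorine, an amine or a carboxylic acid on this ring would read in this assay remains open.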